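The source may report more compounds than this note shows. Statements on the series, on what has been measured and on what is new or still open speak of the compounds shown alone.

Working notes on the series in a functional assay on HL-60 cells (Homo sapiens) for cytotoxicity, read by MTT assay, with a stated time of 24 h; a lower number here means a stronger inhibitor, a higher number a weaker inhibitor: compound 1 `CC(C)(C)OC(=O)N1CCCN(CCCCCOc2c(Br)cc(Br)cc2Oc2ccc(Br)cc2Br)CC1` gives 44.8 ug/mL, compound 2 `BrCCCOc1c(Br)cc(Br)cc1Oc1ccc(Br)cc1Br` gives 29.9 ug/mL and compound 3 `CC(=O)Oc1c(Br)cc(Br)cc1Oc1ccc(Br)cc1Br` gives 29.9 ug/mL, so compound 3 stands level with compound 2 and within the scatter of compound 1. Compound 4 `CC(C)(C)C(=O)C(C#N)Oc1c(Br)cc(Br)cc1Oc1ccc(Br)cc1Br` carries cyano((tert-butyl)carbonyl)methyl in place of acetyl on an oxygen on an aromatic ring, (cyano((tert-butyl)carbonyl)methyl in place of acetyl on an oxygen on an aromatic ring). Among the compounds with values here, the only measured step at this oxygen, no change at the digits printed from compound 2 to compound 3 (within the scatter), stays within the scatter. On these data alone, no change beyond the scatter is therefore expected in this assay, although this new group is untested. The estimated step, a 1.0-fold higher number from compound 3 to compound 4 (0.00 log units; within the scatter), is expected to remain small. For compound 4 the expected value is 30 ug/mL, with an estimated range of 14 ug/mL to 58 ug/mL.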

Compound 4, half-maximal inhibitory concentration: 29.2 ug/mL
Estimate against measurement, compound 4: 1.0-fold (0.01 log units) above, and the stated range covers the measured number.
By their numbers in this assay, from the lowest: compounds 4, 2, 3 and 1 (each within the scatter of the next).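

In this assay, the oxygen on an aromatic ring accepts cyano((tert-butyl)carbonyl)methyl, with 9 heavy atoms against the 3 of acetyl, and the step stays within the scatter (a 1.0-fold lower number from compound 3 to compound 4 (0.01 log units; within the scatter)). The step from 3-bromopropyl also stays within the scatter (a 1.0-fold lower number from compound 2 to compound 4 (0.01 log units; within the scatter)), so three unlike groups at this oxygen now read level, one of them with a nitrile. No measurement available here accounts for this flat response. On these data alone, whether a carboxylic acid or a free hydroxyl at this place would move the number beyond the scatter remains open.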